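The source may report more compounds than this note shows. Statements on the series, on what has been measured and on what is new or still open speak of the compounds shown alone.

Compound 1 `Cc1nc(S(C)(=O)=O)ccc1Oc1ncnc(OC2CCN(C(=O)OC3(C(F)(F)F)COC3)CC2)c1F` and compound 2 `Cc1nc(S(C)(=O)=O)ccc1Oc1ncnc(OC2CCN(C(=O)C(C)(C)F)CC2)c1F` share a common core and differ only in the group on a carbonyl carbon. In a functional assay on isolated protein for inhibition of Glucose-dependent insulinotropic receptor (Rattus norvegicus), read by HTRF and cAMP accumulation (on this read-out lower numbers stand for an effect already at smaller amounts and higher numbers for an effect only at larger amounts of compound), compound 1 gives 342 nM, and compound 2 gives 296 nM; the step of a 1.2-fold lower number from compound 1 to compound 2 (0.06 log units; within the scatter) is within the scatter, so compound 2 stands level with compound 1 on the numbers shown. Compound 3 `Cc1nc(S(C)(=O)=O)ccc1Oc1ncnc(OC2CCN(C(=O)c3nc(C(C)(C)F)no3)CC2)c1F` carries a group of 9 heavy atoms (5 carbon, 2 nitrogen, 1 oxygen, 1 fluorine; one five-membered aromatic ring with 3 hetero atoms) in place of a group of 4 heavy atoms (3 carbon, 1 fluorine; no ring), on a carbonyl carbon. For the measured compounds named here, the only measured step concerns the same carbonyl carbon yet exchanges different groups, so for compound 3 no step beyond the scatter is expected in this assay. Compound 3 is therefore estimated at 300 nM, between 100 nM and 1000 nM, an expected step of a 1.0-fold higher number from compound 2 to compound 3 (0.01 log units; within the scatter).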

Compound 3, half-maximal effective concentration: 606 nM
The estimate for compound 3 lay 2.0-fold (0.31 log units) below the measured number; the range from low to high includes it.
By their numbers in this assay, from the lowest: compounds 2, 1 and 3 (each within the scatter of the next, the first and the last beyond it).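

For the compounds shown here, on the carbonyl carbon whose other neighbour is the amide-type nitrogen in a ring, the group does make a modest difference: in this assay replacing 1-fluoro-1-methylethyl with the larger group bearing a five-membered aromatic ring gives a 2.0-fold higher number from compound 2 to compound 3 (0.31 log units; beyond the scatter) and is the first step here beyond the scatter. Set against the (3-(trifluoromethyl)oxetan-3-yl)oxy group, the same ring gives a 1.8-fold higher number from compound 1 to compound 3 (0.25 log units; within the scatter) and stays within the scatter. No supporting evidence accounts for this difference. From the compounds shown here alone, what a primary amine or a carboxylic acid would give on this carbonyl carbon remains open.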